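Acetyl for Methylethenyl at the Aryl Ether Core

A few compounds are considered here, and "the series" means these few. Any claim that something is new, unique, unknown or untested is made for them only; others in the source may bear on it.

Of the compounds shown here, three sharing one core have been measured in an assay on CHO cells with Alpha-2B adrenergic receptor (Homo sapiens) as the target; a lower number here means a smaller maximal response, a higher number a larger maximal response. Compound 1 `CCOc1ccccc1OC(C)C1=NCCN1` gives 0.5, compound 2 `CC(Oc1ccccc1OC1CC1)C1=NCCN1` gives 0.6, and compound 3 `C=C(C)c1ccccc1OC(C)C1=NCCN1` gives 0.4. Compound 3 stands lowest of the three, its gap to compound 1 lying within the scatter and its gap to compound 2 beyond it. The step a number 0.20 lower from compound 2 to compound 3 (beyond the scatter) is the only one among the three that clears the scatter, while a number 0.10 lower from compound 1 to compound 3 (within the scatter) does not.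

Compound 4 `CC(=O)c1ccccc1OC(C)C1=NCCN1` differs from compound 3 in one place: acetyl in place of 1-methylethenyl on an aromatic carbon. Both measured steps that bear on this position end at compound 3 and are small, and neither of them involves an acetyl group, so they offer only loose guidance. The expectation is that the step a number 0.10 higher from compound 3 to compound 4 (within the scatter) stays modest, most likely a drift back toward the values of compound 1 and compound 2 rather than a large move. For compound 4 the estimate in this assay is 0.5, with a range from 0.3 to 0.7.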

Compound 4, intrinsic activity: the largest response reached, as a fraction of the reference agonist's: 0.6
Estimate against measurement, compound 4: 0.10 below; low and high end bracket the measured number.
By their numbers in this assay, from the lowest: compounds 3, 1, 2 and 4 (each within the scatter of the next, the first and the last beyond it).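

In this assay, acetyl in place of 1-methylethenyl, a change of the same heavy-atom count that adds one hydrogen-bond acceptor, gives a number 0.20 higher from compound 3 to compound 4 (beyond the scatter). The acetyl compound does not separate from the two compounds with an oxygen-linked group at this position, giving no change at the digits printed from compound 2 to compound 4 (within the scatter) and a number 0.10 higher from compound 1 to compound 4 (within the scatter), so compound 3 now lies beyond the scatter of two neighbours while remaining within it of compound 1. No measurement available here accounts for this step.

The compounds shown leave open how an amine, a carboxylic acid or a longer chain on this aromatic carbon would read in this assay. They also leave open whether acetyl in place of 1-methylethenyl would give a step of similar size on any other core.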